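The compounds below may be only part of what the source reports. "The series", "measured", "known", "first", "only" and "open" are said of these compounds alone.

Compound 2 `COc1cc(Cl)cc(-c2nn(-c3cccc(NC(=O)Nc4ccc(Cl)c(Cl)c4)c3)cc2-c2ccncc2)c1` and compound 1 `COc1cc(Cl)cc(-c2nn(-c3cccc(NC(=O)Nc4cc(C(F)(F)F)cc(C(F)(F)F)c4)c3)cc2-c2ccncc2)c1` share one core and were both examined in a functional assay on SK-MEL-2 cells (Homo sapiens) for inhibition, read by sulforhodamine B assay, with a stated time of 48 h, tested at 100 uM; on this read-out higher numbers stand for a weaker effect at the one concentration tested and lower numbers for a stronger effect. In this assay compound 1 gives -83%, while compound 2 gives -70%. Of the two numbers recorded, compound 2 holds the higher one, so on this read-out it shows the weaker effect, and its gap to compound 1, the nearest neighbour, lies beyond the usual scatter of the measurement.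

Compound 3 `COc1cc(Cl)cc(-c2nn(-c3cccc(NC(=O)Nc4cccc(C(F)(F)F)c4)c3)cc2-c2ccncc2)c1` has not yet been measured in this assay . It differs from compound 2 in one place: 3-(trifluoromethyl)phenyl in place of 3,4-dichlorophenyl on an amide-type nitrogen. Going by the values given here, no step between two measured compounds describes this exchange, so the only anchor is compound 2 itself and the fact that compound 1, with a different group on the same amide-type nitrogen, reads lower. In the absence of a counted step, the change from compound 2 to compound 3 is expected to be small, a number 2 percentage points lower from compound 2 to compound 3 (within the scatter), and not clearly beyond the scatter in either direction. Compound 3 is therefore estimated at -72% in this assay , with a range from -90% to -50%.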

Compound 3, a percentage reported as activity, at one concentration (the size of the read-out at that concentration, not a potency): -68%
For compound 3 the middle estimate is 4 percentage points below the measured one; measured number inside the range.
By their numbers in this assay, from the lowest: compound 1; then compounds 2 and 3 (each within the scatter of the next).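

In this assay, putting 3-(trifluoromethyl)phenyl in place of 3,4-dichlorophenyl on the amide-type nitrogen gives a number 2 percentage points higher from compound 2 to compound 3 (within the scatter), so on this read-out the two groups cannot be told apart, and the two chlorines are matched by a single trifluoromethyl group. The other step shows what the earlier pair could not: with hydrogen in place of trifluoromethyl on an aromatic carbon there is a number 15 percentage points higher from compound 1 to compound 3 (beyond the scatter), which ties the stronger effect of compound 1 to its second trifluoromethyl group, although this rests on this one pair of compounds alone. Nothing at hand explains either step.

The aromatic ring at this position carries only chlorine or trifluoromethyl in the compounds shown, so it remains open whether a methoxy group, an amine or a carboxylic acid there would read like compound 3 or like compound 1. As far as these compounds go, since the read-out comes from a single concentration, it also remains open whether these steps would hold as differences in effect at other concentrations.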